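Exchanging the aryl amine substituent on a shared core

The source may hold more compounds than are shown below. What is called first, only, known or untested is meant among the compounds shown, and "the series" means these compounds.

Compound 2 `Cc1ccc(NC2=CC(=O)c3nc4n(c3C2=O)[C@H]2OC[C@@H](O)[C@H]2OC4)cc1C` gives the lowest of the two numbers measured in a functional assay on HeLa cells (Homo sapiens) for inhibition, read by sulforhodamine B assay (on this read-out higher numbers stand for weaker inhibition and lower numbers for stronger inhibition), namely 2690 nM. Compound 3 `CCCc1ccc(NC2=CC(=O)c3c(nc4n3[C@H]3OC[C@@H](O)[C@H]3OC4)C2=O)cc1` gives 6030 nM in this assay. Compound 1 `COc1cccc(NC2=CC(=O)c3c(nc4n3[C@H]3OC[C@@H](O)[C@H]3OC4)C2=O)c1` reaches only the limit of this assay, > 8000 nM, which is not a number (the limit of > 8000 nM in this assay, at which 1 of the 3 values shown sits). The one measured step among these, an at least 1.3-fold lower number from compound 1 to compound 3 (0.12 log units; that floor lies within the scatter), is small. Compound 4 `O=C1C=C(Nc2cccc(F)c2)C(=O)c2c1nc1n2[C@H]2OC[C@@H](O)[C@H]2OC1` differs from compound 2 in one place: 3-fluorophenyl in place of 3,4-dimethylphenyl on an amine nitrogen. No measured step exchanges a 3,4-dimethylphenyl for a 3-fluorophenyl, so the expectation rests on the narrow spread of the numbers shown. A modest move toward weaker inhibition is expected, a 1.9-fold higher number from compound 2 to compound 4 (0.27 log units; within the scatter). Compound 4 is therefore estimated at 5000 nM in this assay, with a range from 2000 nM to 12000 nM.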

Compound 4, half-maximal inhibitory concentration: 6440 nM
For compound 4 the middle estimate is 1.3-fold (0.11 log units) below the measured one; measured number inside the range.
By their numbers in this assay, from the lowest: compound 2; then compounds 3 and 4 (each within the scatter of the next). At a limit, above all of these: compound 1.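

Among the compounds shown here, on the amine nitrogen of the shared core, this exchange of one aryl group for another gives the first step with a number at both ends, and in this assay it reads a 2.4-fold higher number from compound 2 to compound 4 (0.38 log units; beyond the scatter). So the choice of aryl group at this place can shift the read-out beyond the scatter. Nothing shown bears on why this happens. Going by these compounds, it remains open how a simple phenyl or a 3-methylphenyl would read at this nitrogen, which could separate the loss of the methyl groups from the arrival of fluorine. A cyclohexyl group or a straight alkyl chain in place of the aryl ring is also left open.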